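The compounds below may be only part of what the source reports. "The series", "measured", "known", "first", "only" and "open" are said of these compounds alone.

Three compounds built on one shared core carry different groups on a carbonyl carbon bonded to an amide-type nitrogen, and all were tested in an assay on LtK cells with ATP-sensitive inward rectifier potassium channel 11 (Homo sapiens) as the target; on this read-out higher numbers stand for an effect only at larger amounts of compound and lower numbers for an effect already at smaller amounts. Compound 1 `CCCC(C)C(=O)Nc1c(C(O)(C(F)(F)F)C(F)(F)F)ccc2ccccc12` reaches only a limit of this assay, > 10000 nM, which is not a measured number (the limit of > 10000 nM in this assay, at which 1 of the 3 values shown sits). Compound 2 `COCC(=O)Nc1c(C(O)(C(F)(F)F)C(F)(F)F)ccc2ccccc12` gives 213 nM in this assay, and compound 3 `O=C(NCCCCCCCl)Nc1c(C(O)(C(F)(F)F)C(F)(F)F)ccc2ccccc12` gives 4840 nM. Of the two plain numbers, compound 3 stands highest, with compound 2 as its nearest neighbour, and the step of a 23-fold higher number from compound 2 to compound 3 (1.36 log units; beyond the scatter) is large and beyond the scatter. From the limit of compound 1 the steps are an at least 46-fold lower number from compound 1 to compound 2 (1.67 log units; beyond the scatter) and an at least 2.0-fold lower number from compound 1 to compound 3 (0.31 log units; beyond the scatter).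

Compound 4 `O=C(Nc1c(C(O)(C(F)(F)F)C(F)(F)F)ccc2ccccc12)c1ccccc1Cl` differs from compound 3 by 2-chlorophenyl in place of (6-chlorohexyl)amino on a carbonyl carbon. All three measured steps change the group at this same carbonyl carbon and bear on the new one; they range from modest to large. Within the data shown here, none of the measured compounds carries an aromatic ring at this place, so the expectation rests loosely on them. A lower number is expected for compound 4, as compound 3 with its value of 4840 nM holds the highest plain number here. Compound 4 is therefore estimated at 1500 nM, within 300 nM to 8000 nM. The expected step is a 3.2-fold lower number from compound 3 to compound 4 (0.51 log units; beyond the scatter).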

Compound 4, half-maximal effective concentration: 2040 nM
Compound 4: middle estimate off by 1.4-fold (0.13 log units), on the low side; measured number inside the range.
By their numbers in this assay, from the lowest: compound 2; then compound 4; then compound 3. At a limit, above all of these: compound 1.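

With 2-chlorophenyl, the carbonyl carbon carries an aromatic ring for the first time among these compounds, and in this assay the ring gives a measured number rather than a limit, with a 2.4-fold lower number from compound 3 to compound 4 (0.38 log units; beyond the scatter) when it replaces (6-chlorohexyl)amino. Methoxymethyl remains the group with the lowest number of the series, with a 9.6-fold higher number from compound 2 to compound 4 (0.98 log units; beyond the scatter), so this ring takes a middle place and does not set a new low. Against 1-methylbutyl the step reads an at least 4.9-fold lower number from compound 1 to compound 4 (0.69 log units; beyond the scatter), which gives only a minimum size for the change, since compound 1 stands at a limit and not at a plain number: the limit of > 10000 nM in this assay, at which 1 of the 4 values shown sits.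

The compounds shown leave open how much of the result belongs to the ring and how much to its chlorine, which plain phenyl or a pyridine ring at the same place would help to separate. Going by these compounds, it also remains open whether an ether chain longer than methoxymethyl, such as ethoxymethyl or 2-methoxyethyl, would stay close to compound 2 or move towards the higher numbers of compound 3 and compound 4.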